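Swapping a Hydroxyazetidine for a Cyclobutylmethoxy Group

A few compounds are considered here, and "the series" means these few. Any claim that something is new, unique, unknown or untested is made for them only; others in the source may bear on it.

Of the compounds shown here, two have so far been tested in a functional assay on cells for antagonist activity at Free fatty acid receptor 1 (Homo sapiens), read by TR-FRET and inositol phosphate accumulation, with a stated time of 2 h; on this read-out higher numbers stand for weaker inhibition and lower numbers for stronger inhibition. Compound 1 `Cc1cc(COc2c(F)ccc(F)c2F)nc(-c2ccccn2)n1` gives 1580 nM in this assay. Compound 2 `OC1CN(c2cc(COc3ccc(F)c(F)c3F)nc(-c3ccccn3)n2)C1` gives 3160 nM in this assay; its number is the higher of the two, but the gap to compound 1 lies within the scatter of repeated measurements, so no order between them can be claimed. Compound 3 `Fc1ccc(OCc2cc(OCC3CCC3)nc(-c3ccccn3)n2)c(F)c1F` has not yet been measured. It differs from compound 2 in one place: cyclobutylmethoxy in place of 3-hydroxyazetidin-1-yl on an aromatic carbon. For the measured compounds named here, no measured pair differs in just this way, so the data give no guide to the size or direction of the step. The step expected here is a 1.3-fold lower number from compound 2 to compound 3 (0.10 log units; within the scatter), with no direction claimed beyond the scatter. Compound 3 is therefore estimated to give 2500 nM in this assay, within a range from 700 nM to 9000 nM.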

Compound 3, half-maximal inhibitory concentration: 12.6 nM
The estimate for compound 3 lay 200-fold (2.30 log units) above the measured number; the measured number lies below the stated range.
By their numbers in this assay, from the lowest: compound 3; then compounds 1 and 2 (each within the scatter of the next).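

At this position on the shared core, the choice of group matters greatly in this assay, something the two earlier compounds could not show. Putting cyclobutylmethoxy in place of 3-hydroxyazetidin-1-yl on this aromatic carbon gives a 250-fold lower number from compound 2 to compound 3 (2.40 log units; beyond the scatter) and so counts as a large step, well beyond the scatter. Several things change at once, since the ring loses its nitrogen, the group loses its one hydrogen-bond donor and gains a linking oxygen, and nothing at hand shows why the number falls.

Which of these differences carries the step remains open. A cyclobutylmethylamino group, with nitrogen as the link, and a plain butoxy chain, with no ring, would help to separate the part played by the linking oxygen from that of the cyclobutyl ring.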